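The source may report more compounds than this note shows. Statements on the series, on what has been measured and on what is new or still open speak of the compounds shown alone.

Working notes on the series. Three compounds have numbers in a functional assay on CHO cells with adenosine receptor A1 (Homo sapiens) as the target, read by cAMP accumulation and immunoassay, with a stated time of 6 min, tested at 1 uM; on this read-out higher numbers stand for a weaker effect at the one concentration tested and lower numbers for a stronger effect. Compound 1, `COc1ccc(N2CCN(Cc3csc(N)c3C(=O)c3ccc(Cl)cc3)CC2)cc1`, gives -15%; compound 2, `Nc1scc(CN2CCN(c3cccnc3)CC2)c1C(=O)c1ccc(Cl)cc1`, gives -2.7%; compound 3, `Nc1scc(CN2CCN(c3ccc(C(F)(F)F)cc3)CC2)c1C(=O)c1cccc(C(F)(F)F)c1`, gives -27%. Compound 2 thus stands highest of the three, with compound 1 nearest and compound 3 furthest. Among the measured compounds shown here, the one step that changes the group on the amine nitrogen in the ring is a number 12.3 percentage points higher from compound 1 to compound 2 (beyond the scatter). Compound 4, `Nc1scc(CN2CCN(c3ccccc3Cl)CC2)c1C(=O)c1ccc(Cl)cc1`, is not yet measured; it differs from compound 2 by 2-chlorophenyl in place of pyridin-3-yl on an amine nitrogen in a ring. For the measured compounds named here, only the step from compound 1 to compound 2 bears on this change, and it was modest, so a step of similar size back toward compound 1 is expected, estimated as a number 9.3 percentage points lower from compound 2 to compound 4 (within the scatter). The value of compound 4 is expected at -12%, within -30% to 6%.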

Compound 4, a percentage reported as activity, at one concentration (the size of the read-out at that concentration, not a potency): -5.2%
Compound 4: the middle estimate sits 6.8 percentage points below what was measured, and the stated range covers the measured number.
By their numbers in this assay, from the lowest: compound 3; then compounds 1, 4 and 2 (each within the scatter of the next, the first and the last beyond it).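

On the amine nitrogen in the ring, 2-chlorophenyl in place of pyridin-3-yl gives in this assay a number 2.5 percentage points lower from compound 2 to compound 4 (within the scatter), and 2-chlorophenyl in place of 4-methoxyphenyl gives a number 9.8 percentage points higher from compound 1 to compound 4 (within the scatter). Compound 4 therefore cannot be told apart from either neighbour, although the step between those two lies beyond the scatter, and a carbon-only ring here serves as well as a ring with a hetero atom. No evidence bears on the reason for this. The compounds shown leave open whether this position needs an aromatic ring at all. A cyclohexyl group or a longer alkyl chain on that nitrogen would test this.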